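Acetyl in Place of Furan-2-yl: Cytotoxicity Expected Unchanged

The source may report more compounds than this note shows. Statements on the series, on what has been measured and on what is new or still open speak of the compounds shown alone.

Compound 1 `O=C(Nc1cccc(-c2ccco2)c1)C1CCCN(C(=O)c2cc(C(F)(F)F)cc(C(F)(F)F)c2)C1` was tested in an ADME assay on PC-3 cells (Homo sapiens) for cytotoxicity, read by WST assay, tested at 100 uM (on this read-out lower numbers stand for less inhibition and higher numbers for more inhibition at the one concentration tested (going by the name of the read-out)), where compound 1 gives 0%. Compound 2 `COC(=O)c1cccc(C(=O)N2CCCC(C(=O)Nc3ccc(Cl)cc3)C2)c1` gives 0% in this assay, so compound 1 stands level with compound 2, the gap lying within the scatter. Compound 3 `CC(=O)c1cccc(NC(=O)C2CCCN(C(=O)c3cc(C(F)(F)F)cc(C(F)(F)F)c3)C2)c1` differs from compound 1 by acetyl in place of furan-2-yl on an aromatic carbon. Within the data shown here, no step between measured compounds is available to size this change. Because compound 1 gives 0%, no shift beyond the scatter is expected for compound 3, and the expected step is no change at the digits printed from compound 1 to compound 3 (within the scatter). Compound 3 is estimated at 0%, between -10% and 10%.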

Compound 3, a percentage reported as inhibition, at one concentration (the size of the read-out at that concentration, not a potency): 0%
The estimate for compound 3 equals the measured number at the digits printed; low and high end bracket the measured number.
By their numbers in this assay, from the lowest: compounds 1, 2 and 3 (each within the scatter of the next).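

In this assay, among these compounds, acetyl in place of furan-2-yl on this aromatic carbon shows no change at the digits printed from compound 1 to compound 3 (within the scatter), the only step available at this position. It shows that the five-membered aromatic ring can be exchanged for a group with no ring without a shift beyond the scatter. No evidence bearing on the reason for this result is available. From the compounds shown here alone, with compound 3 at 0%, it remains open whether an amine or a carboxylic acid on this aromatic carbon would raise the read-out. Going by these compounds, whether a change elsewhere on the shared core would do so also remains open.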